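Series notes: removing the amide acyl group from compound 3

This account rests on a few compounds, and the source may have more. Where it says the series, first, only, none or still open, it means among the compounds named here.

Compound 3 `Cc1ccccc1C(=O)N(Cc1ccc(C(=O)NO)cc1)Cc1nnnn1C1CCCCC1` gives the lowest number of the three measured in an assay on isolated protein for inhibition of protein deacetylase HDAC6 (Homo sapiens), read by fluorescence, with a stated time of 90 min (on this read-out lower numbers stand for stronger inhibition and higher numbers for weaker inhibition), at 60 nM. Compound 1 `O=C(NO)c1ccc(CN(Cc2nnnn2C2CCCCC2)C(=O)c2ccccc2)cc1` gives 70 nM in this assay, and the step of a 1.2-fold lower number from compound 1 to compound 3 (0.07 log units; within the scatter) lies within the scatter. Compound 2 `O=C(NO)c1ccc(CNCc2nnnn2Cc2ccccc2)cc1` gives 100 nM in this assay, also within the scatter of compound 3.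

Compound 4 `O=C(NO)c1ccc(CNCc2nnnn2C2CCCCC2)cc1` differs from compound 3 by hydrogen in place of (2-methylphenyl)carbonyl on an amine nitrogen. Going by the values given here, no measured step covers this change: the only step on record, from compound 1 to compound 3, alters the acyl ring rather than removing it. The nearest guide is compound 2, a secondary amine on a differently substituted tetrazole, whose value in this assay sits close to those of the acylated compounds 1 and 3. On that basis the step of a 1.7-fold higher number from compound 3 to compound 4 (0.22 log units; within the scatter) is expected to stay small, if anything toward a higher number. Compound 4 is therefore estimated at 100 nM in this assay, with a range of 40 nM to 250 nM.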

Compound 4, half-maximal inhibitory concentration: 120 nM
The estimate for compound 4 lay 1.2-fold (0.08 log units) below the measured number, within the range that was stated.
By their numbers in this assay, from the lowest: compounds 3, 1, 2 and 4 (each within the scatter of the next).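

On the amine nitrogen, the whole acyl group can go without the number leaving the scatter in this assay: the step is a 2.0-fold higher number from compound 3 to compound 4 (0.30 log units; within the scatter) when (2-methylphenyl)carbonyl leaves and a 1.7-fold higher number from compound 1 to compound 4 (0.23 log units; within the scatter) when benzoyl leaves. Earlier compounds covered only a methyl on the acyl ring, and with the amine free, the change on the aromatic nitrogen is also small, at a 1.2-fold higher number from compound 2 to compound 4 (0.08 log units; within the scatter) for cyclohexyl in place of benzyl. No supporting data bear on why these steps stay so small.

Still open, going by these compounds, is whether an acetyl or a methyl group on the amine nitrogen would also stay within the scatter. On these data alone, it is equally open whether a longer chain or an amine on the aromatic nitrogen would hold the number in this range.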